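The compounds below may be only part of what the source reports. "The series", "measured", "known", "first", "only" and "open" are said of these compounds alone.

Working notes on the series.

Three compounds have been run in an ADME assay on MRC5 cells (Homo sapiens) for cytotoxicity; a lower number here means that less compound is tolerated, a higher number that more compound is tolerated. Compound 1 `Cc1cn([C@@H]2C[C@H](O)[C@@H](CNC(=S)Nc3ccc(OCc4ccccc4)cc3)O2)c(=O)[nH]c1=O` gives a limit of the assay, > 50000 nM, rather than a number. Compound 2 `Cc1cn([C@@H]2C[C@H](O)[C@@H](CNC(=O)Nc3ccc(OC4CCOCC4)cc3)O2)c(=O)[nH]c1=O` likewise reaches only a limit in this assay, > 50000 nM. Compound 3 `Cc1cn([C@@H]2C[C@H](O)[C@@H](CNC(=O)Nc3ccc(Cc4ccccc4)cc3)O2)c(=O)[nH]c1=O` again returns only a limit, > 50000 nM.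

Within the data shown here, the one step between two measured compounds that differ in a single place, a step that the two limits leave unreadable from compound 2 to compound 3, cannot be read, as both ends are limits. Among the measured compounds shown here, all three values sit at the same limit, (the limit of > 50000 nM in this assay, at which 3 of the 3 values shown sit), so nothing measured so far shows any compound to be less well tolerated than another.

Compound 4 `Cc1cn([C@@H]2C[C@H](O)[C@@H](CNC(=O)Nc3ccc(OCc4ccc(C(C)(C)C)cc4)cc3)O2)c(=O)[nH]c1=O` is the next member. Compared with compound 3 the change is (4-(tert-butyl)benzyl)oxy in place of benzyl on an aromatic carbon, at the place described there. For the measured compounds named here, no measured step bears on this change directly; the only step on record, from compound 2 to compound 3, is unreadable, and every value in this assay sits at the limit, (the limit of > 50000 nM in this assay, at which 3 of the 3 values shown sit). The step of a number no higher from compound 3 to compound 4 (the limit leaves the size open) is therefore expected to be none beyond the scatter, with the result most likely a limit again. Compound 4 is expected to give about 50000 nM in this assay, within 20000 nM to 100000 nM.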

Compound 4, half-maximal cytotoxic concentration: > 50000 nM
Compound 4 gave a limit, no number; the forecaster's own chance of this, stated with the estimate: 80%; the middle value lies on the limit itself.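

Compound 4 also returns only a limit, so the steps to it from compound 2 and from compound 3 cannot be read, as both ends of each step are limits. All values shown stand at the same point: the limit of > 50000 nM in this assay, at which 4 of the 4 values shown sit.

The compounds shown leave open whether compound 1, compound 2, compound 3 and compound 4 differ at all in this assay, and whether any change on the shared core would give a number rather than a limit.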